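Methyl on the Anilide Ring: Ether Core versus Thioether Core

This account rests on a few compounds, and the source may have more. Where it says the series, first, only, none or still open, it means among the compounds named here.

Compound 1 `Cc1cc(C)nc(Oc2ccc(NC(=O)Nc3ccccc3)cc2)n1` and compound 3 `Cc1cc(C)nc(Sc2ccc(NC(=O)Nc3ccccc3)cc2)n1` share a urea but differ in their cores, and the difference between the two cores is not broken down here. In a functional assay on KB cells (Homo sapiens) for cytotoxicity, read by MTT assay, with a stated time of 3 days (on this read-out lower numbers stand for stronger inhibition and higher numbers for weaker inhibition), compound 1 gives only a limit, > 50000 nM. Compound 2 `Cc1cccc(NC(=O)Nc2ccc(Oc3nc(C)cc(C)n3)cc2)c1` carries methyl in place of hydrogen on an aromatic carbon. In this assay compound 2 also gives only a limit, > 50000 nM. The step that the two limits leave unreadable from compound 1 to compound 2 therefore cannot be read, as the limit of > 50000 nM in this assay, at which 2 of the 3 values shown sit, shows. For the measured compounds named here, compound 3 is the one compound with a number: in this assay compound 3 gives 25700 nM. Compound 4 `Cc1cccc(NC(=O)Nc2ccc(Sc3nc(C)cc(C)n3)cc2)c1` carries the same change, (methyl in place of hydrogen on an aromatic carbon). With the earlier step unreadable, the expectation for compound 4 rests on compound 3 alone, which gives 25700 nM in this assay. The expected step is a 1.4-fold higher number from compound 3 to compound 4 (0.13 log units; within the scatter), a small one. Compound 4 is estimated at 35000 nM, between 12000 nM and 100000 nM.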

Compound 4, half-maximal inhibitory concentration: 47800 nM
Compound 4: the middle estimate sits 1.4-fold (0.14 log units) below what was measured; low and high end bracket the measured number.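

On the thioether core, methyl in place of hydrogen on an aromatic carbon gives a 1.9-fold higher number from compound 3 to compound 4 (0.27 log units; within the scatter) in this assay, so on this core the change has no effect that can be told apart from the usual scatter. On the ether core, compound 1 and compound 2 both give only a limit of the assay, so the step between them cannot be read: the limit of > 50000 nM in this assay, at which 2 of the 4 values shown sit. One readable step therefore shows neither that the result of this change carries over from one core to the other nor that it fails to.

Going by these compounds, it remains open whether a group other than methyl on this ring, such as an amine, a carboxylic acid or a longer chain, would shift the number beyond the scatter. On these data alone, it also remains open how any such group would behave on the ether core, where a readable number would be needed for a comparison.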